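A few compounds are considered here, and "the series" means these few. Any claim that something is new, unique, unknown or untested is made for them only; others in the source may bear on it.

Measured so far:
compound 1 `O=C(/C=C\c1cccc([N+](=O)[O-])c1)N1N=C(c2ccncc2)OC1c1c[nH]c2ccccc12` – an ADME assay on HeLa cells (Homo sapiens) for cytotoxicity, read by MTT assay, with a stated time of 72 h; a higher number here means a weaker inhibitor of growth, a lower number a stronger inhibitor of growth: > 30 ug/mL
compound 2 `O=C(/C=C\c1cccc(Cl)c1Cl)N1N=C(c2ccncc2)OC1c1c[nH]c2ccccc12` – this assay: > 30 ug/mL

In this assay the result for compound 1 is a limit of the assay, not a number. The result for compound 2 is likewise a limit, not a number. The step that the two limits leave unreadable from compound 1 to compound 2 therefore cannot be given a size, and compound 2 stands nowhere definite on the numbers shown: it is known only to sit at the same limit as the one other value, which is the limit of > 30 ug/mL in this assay, at which 2 of the 2 values shown sit.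

Compound 3 `O=C(/C=C/c1c(Cl)cccc1Cl)N1N=C(c2ccncc2)OC1c1c[nH]c2ccccc12` is a rearranged version of compound 2: 2-(2,6-dichlorophenyl)ethenyl in place of 2-(2,3-dichlorophenyl)ethenyl on a carbonyl carbon. For the measured compounds named here, no measured step bears readably on this change, since the single step from compound 1 to compound 2 is unreadable. The expectation for compound 3 rests only on compound 2 sitting at its limit, > 30 ug/mL, and so the estimated step that the limit leaves unreadable from compound 2 to compound 3 is taken as none beyond the scatter. Compound 3 is estimated at 40 ug/mL in this assay, with an expected range from 15 ug/mL to 100 ug/mL, and most likely it will again come back as a limit rather than a number.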

Compound 3, concentration for 50% growth inhibition: > 30 ug/mL
Compound 3: no number, only a limit (the forecaster's own chance of this, stated with the estimate: 75%); the middle value does not contradict the limit.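

Compound 3 gives only a limit of the assay in this assay, so no step among compound 1, compound 2 and compound 3 can be read: the limit of > 30 ug/mL in this assay, at which 3 of the 3 values shown sit.

The compounds shown leave open whether 2-(2,6-dichlorophenyl)ethenyl, 2-(2,3-dichlorophenyl)ethenyl and 2-(3-nitrophenyl)ethenyl on the carbonyl carbon differ at all in this assay.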